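A few compounds are considered here, and "the series" means these few. Any claim that something is new, unique, unknown or untested is made for them only; others in the source may bear on it.

Measured so far in this assay:
compound 1, `c1ccc(-c2ccc(Cn3cncc3CNc3cccc(-c4ccccc4)c3)cc2)cc1`: 10000 nM
compound 2, `COC(=O)c1ccc(NCc2cncn2Cc2cccc([N+](=O)[O-])c2)cc1-c1ccccc1`: > 10000 nM

For the measured compounds named here, in a toxicity assay on NIH3T3 cells (Mus musculus) for cytotoxicity, read by resazurin assay (on this read-out lower numbers stand for an effect already at smaller amounts and higher numbers for an effect only at larger amounts of compound), compound 1 gives 10000 nM, the only plain number. Compound 2 reaches only a limit of the assay, > 10000 nM. Going by the values given here, compound 1 therefore stands as the sole compound with a measured number, the other value being a limit (the limit of > 10000 nM in this assay, at which 1 of the 2 values shown sits).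

Compound 3, `c1ccc(-c2ccc(Cn3cncc3CNc3ccc(-c4nc5ccccc5o4)c(-c4ccccc4)c3)cc2)cc1`, has not yet been measured in this assay. It differs from compound 1 by 1,3-benzoxazol-2-yl in place of hydrogen on an aromatic carbon. Among the compounds with values here, no measured pair with a single change is available to set the size of such a step, so no direction can be read from the data. The expected step from compound 1 to compound 3 is estimated as no change at the digits printed from compound 1 to compound 3 (within the scatter), that is, none beyond the usual scatter. Compound 3 is expected to give about 10000 nM in this assay, in the range 4000 nM to 25000 nM.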

Compound 3, half-maximal effective concentration: > 10000 nM
Compound 3: only a limit was reported; the forecaster's own chance of this, stated with the estimate: 40%; the middle value lies on the limit itself.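

In this assay, for the compounds shown here, this is the first step that changes a single place, the aromatic carbon ortho to a phenyl group and para to a large group: a number no lower from compound 1 to compound 3 (the limit leaves the size open). Compound 3 gives only a limit of the assay, > 10000 nM. 1,3-Benzoxazol-2-yl in place of hydrogen at this position therefore brings no shift towards an effect at smaller amounts, while the size of the step cannot be read: the limit of > 10000 nM in this assay, at which 2 of the 3 values shown sit.

The compounds shown leave open whether an amine or a carboxylic acid on this same carbon would give a plain number in this assay. They also leave open whether 1,3-benzoxazol-2-yl would give the same outcome on the core of compound 2.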